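A few compounds are considered here, and "the series" means these few. Any claim that something is new, unique, unknown or untested is made for them only; others in the source may bear on it.

Compound 1 `C/C(=N\NC(=O)c1cccc(S(=O)(=O)N2CCOCC2)c1)c1cccc(N)c1`: in a functional assay on MCF7 cells (Homo sapiens) for antiproliferative activity, read by MTT assay, with a stated time of 72 h (on this read-out higher numbers stand for weaker inhibition and lower numbers for stronger inhibition), compound 1 gives > 100000 nM, which is a limit of the assay rather than a number.
Compound 2 `C/C(=N\NC(=O)c1cccc(S(=O)(=O)N2CCOCC2)c1)c1ccccc1O`: in this assay compound 2 gives 5400 nM.
Compound 3 `O=C(N/N=C/c1ccccn1)c1cccc(S(=O)(=O)N2CCOCC2)c1`: in this assay compound 3 gives > 100000 nM, again a limit of the assay.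

Compound 3 therefore stands at the limit of > 100000 nM in this assay, at which 2 of the 3 values shown sit. Compound 4 `CCOc1cccc(/C=N/NC(=O)c2cccc(S(=O)(=O)N3CCOCC3)c2)c1O` differs from it by 3-ethoxy-2-hydroxyphenyl in place of pyridin-2-yl on a carbon with a double bond to nitrogen. For the measured compounds named here, the one measured step that bears on this is an at least 18-fold lower number from compound 1 to compound 2 (1.26 log units; beyond the scatter), where a 2-hydroxyphenyl group on the same carbon brought the number down from a limit to a measured value. A hydroxyphenyl group enters here too, so a large drop in this assay is expected, estimated as an at least 12-fold lower number from compound 3 to compound 4 (1.09 log units; beyond the scatter). Compound 4 is thus expected to give about 8000 nM, with a range from 2000 nM to 60000 nM.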

Compound 4, half-maximal inhibitory concentration: 19300 nM
Beside the measured number, compound 4's estimate is 2.4-fold (0.38 log units) below it, and the stated range covers the measured number.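

Replacing pyridin-2-yl with 3-ethoxy-2-hydroxyphenyl on this carbon turns a compound without a measurable number into one with a measured value in this assay, giving an at least 5.1-fold lower number from compound 3 to compound 4 (0.71 log units; beyond the scatter). This is a second case, after compounds 1 and 2, in which a hydroxyphenyl compound gives a measured value, here with an added ethoxy group. The value for compound 3 is a limit, so the true size of the step stays unknown: the limit of > 100000 nM in this assay, at which 2 of the 4 values shown sit.

On these data alone, the hydroxy group, the ethoxy group and the carbon-only ring all enter together, so their separate shares remain open. A 3-ethoxyphenyl group, a 2-hydroxyphenyl group or a 3-propoxy-2-hydroxyphenyl group on this carbon would help to separate them.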